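Swapping cyano for methyl on compound 2

The source may hold more compounds than are shown below. What is called first, only, known or untested is meant among the compounds shown, and "the series" means these compounds.

In an ADME assay on HepG2 cells (Homo sapiens) for cytotoxicity, read by CellTiter-Glo, with a stated time of 48 h (on this read-out lower numbers stand for higher toxicity in this test and higher numbers for lower toxicity in this test), compound 2 (`N#Cc1cnc(NC(=O)CCCOc2ccccc2)s1`) reads 4000 nM, and compound 3 (`O=C(CCCOc1cccc(C(F)(F)F)c1)Nc1ncc(Cl)s1`) reads 2500 nM, within the scatter of it. Compound 1 (`O=C(CCCOc1ccccc1)Nc1ncc(Br)s1`) reads 1600 nM and is clearly lower than compound 2. Compound 4 (`Cc1cnc(NC(=O)CCCOc2ccccc2)s1`) has not yet been measured and carries methyl in place of cyano on an aromatic carbon. For the measured compounds named here, the one measured step at this place, a 2.5-fold higher number from compound 1 to compound 2 (0.40 log units; beyond the scatter) for cyano in place of bromo, was modest and says nothing direct about methyl. A small change is therefore expected, and the estimated step, a 1.3-fold lower number from compound 2 to compound 4 (0.12 log units; within the scatter) in size, stays within the scatter. Compound 4 is expected to read 3000 nM (1200 nM to 8000 nM) .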

Compound 4, half-maximal cytotoxic concentration: 9000 nM
Compound 4: the middle estimate sits 3.0-fold (0.48 log units) below what was measured; measured number outside the range, above it.
By their numbers in this assay, from the lowest: compounds 1, 3 and 2 (each within the scatter of the next, the first and the last beyond it); then compound 4.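

In this assay, methyl gives a higher number than either of the other two groups tried at this position on the same core (a 2.3-fold higher number from compound 2 to compound 4 (0.35 log units; beyond the scatter); a 5.6-fold higher number from compound 1 to compound 4 (0.75 log units; beyond the scatter)). The position therefore moves this read-out further than the swap from bromo to cyano alone had shown, with bromo, cyano and methyl in rising order. No measurement here explains why methyl reads highest. Still open, from the compounds shown here alone, is whether an amine, a methoxy group or a longer chain such as ethyl at this position would read higher still. Also open, going by these compounds, is whether methyl would give a similar step on the trifluoromethyl-bearing partner, compound 3.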